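This account rests on a few compounds, and the source may have more. Where it says the series, first, only, none or still open, it means among the compounds named here.

Measured so far in a functional assay on HepG2 cells (Mus musculus) for antiproliferative activity against HepG2 (Homo sapiens), read by MTT assay, with a stated time of 48 h; on this read-out lower numbers stand for stronger inhibition and higher numbers for weaker inhibition:
compound 1 `COc1cccc(C(=O)Nc2nnc(/C=C/c3cc(OC)c(OC)c(OC)c3Br)s2)c1`: 120 nM
compound 2 `COc1cc(/C=C/c2nnc(NC(=O)c3cccc(O)c3)s2)c(Br)c(OC)c1OC`: 220 nM
compound 3 `COc1cccc(C(=O)Nc2nnc(/C=C/c3cc(OC)c(OC)c(OC)c3)s2)c1`: 270 nM

Compound 3 stands at 270 nM, within the scatter of compound 2 at 220 nM. The gap to compound 1 lies beyond the scatter: a 2.3-fold higher number from compound 1 to compound 3 (0.35 log units; beyond the scatter).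

Next in line is compound 4 `COc1cc(/C=C/c2nnc(NC(=O)c3cccc(O)c3)s2)cc(OC)c1OC`. Its difference from compound 3 is hydrogen in place of methyl on an oxygen on an aromatic ring. In words, this is methoxy to hydroxy, or 3-methoxyphenyl to 3-hydroxyphenyl.

The same replacement has been measured once, in the bromo-bearing pair: a 1.8-fold higher number from compound 1 to compound 2 (0.26 log units; within the scatter). That single step points towards a higher number but stays within the scatter, so it is weak evidence. The bromo step from compound 1 to compound 3 concerns another place and only sets the starting point.

A small upward drift is therefore expected, with no step beyond the scatter. The expected change is a 1.6-fold higher number from compound 3 to compound 4 (0.19 log units; within the scatter). In this assay the estimate for compound 4 is 420 nM, expected between 190 nM and 950 nM.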

Compound 4, half-maximal inhibitory concentration: 260 nM
Compound 4: middle estimate off by 1.6-fold (0.21 log units), on the high side, and the stated range covers the measured number.
By their numbers in this assay, from the lowest: compounds 1, 2, 4 and 3 (each within the scatter of the next, the first and the last beyond it).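

Methoxy to hydroxy on the core without bromo gives no readable change in this assay, a 1.0-fold lower number from compound 3 to compound 4 (0.02 log units; within the scatter), so the upward drift in the bromo-bearing pair does not recur. Across the two cores, this change shows no settled direction, and its two steps cannot be separated: the same change on two cores in this assay, a 1.8-fold higher number (0.26 log units; within the scatter) from compound 1 to compound 2 and a 1.0-fold lower number (0.02 log units; within the scatter) from compound 3 to compound 4, 1.9-fold (0.28 log units) apart, within the scatter of two such steps

Hydrogen in place of bromo, now seen on the hydroxy side as well, stays within the scatter there, a 1.2-fold higher number from compound 2 to compound 4 (0.07 log units; within the scatter), and only the step on the methoxy side lies beyond it, yet these two steps cannot be separated either: the same change on two cores in this assay, a 2.3-fold higher number (0.35 log units; beyond the scatter) from compound 1 to compound 3 and a 1.2-fold higher number (0.07 log units; within the scatter) from compound 2 to compound 4, 1.9-fold (0.28 log units) apart, within the scatter of two such steps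

With only methoxy and hydroxy shown on this oxygen-bearing ring carbon, it remains open whether an amine, a carboxylic acid or a longer alkoxy chain there would shift the number beyond the scatter. From the compounds shown here alone, whether bromo matters more on one side than on the other also stays open on two pairs.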